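Toward a dimethylamino analogue of the cinnamoyl sulfonamides

The source may report more compounds than this note shows. Statements on the series, on what has been measured and on what is new or still open speak of the compounds shown alone.

Measured compounds:
- compound 1, `O=C(/C=C/c1ccccc1)NS(=O)(=O)c1ccccc1`, in a functional assay on B16-F10 cells (Mus musculus) for antiproliferative activity, read by ELISA and MTT assay, with a stated time of 48 h (on this read-out higher numbers stand for weaker inhibition and lower numbers for stronger inhibition), gives 3.5 ug/mL
- compound 2, `O=C(/C=C/c1ccccc1)NS(=O)(=O)c1ccc(F)cc1`, in this assay gives 2.1 ug/mL
- compound 3, `O=C(/C=C/c1ccccc1)NS(=O)(=O)c1ccc(Br)cc1`, in this assay gives 3.9 ug/mL

The three compounds share a core and differ only in the group on the sulfonyl-bearing ring. Compound 3 gives the highest of the three numbers, but its nearest neighbour is compound 1, at a 1.1-fold higher number from compound 1 to compound 3 (0.05 log units; within the scatter), and its furthest is compound 2, at a 1.9-fold higher number from compound 2 to compound 3 (0.27 log units; within the scatter); the remaining comparison, a 1.7-fold lower number from compound 1 to compound 2 (0.22 log units; within the scatter), is of the same order. All three steps lie within the scatter, so the three compounds cannot be ranked on these numbers.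

Compound 4, `CN(C)c1ccc(/C=C/C(=O)NS(=O)(=O)c2ccc(Br)cc2)cc1`, is reached from compound 3 by a change on the other ring of the core: dimethylamino in place of hydrogen on an aromatic carbon. For the measured compounds named here, none of the measured steps touches that ring, so none bears directly on this change; what the measured steps do show is that single substitutions on this scaffold have so far moved the read-out by less than the scatter. On that basis no step beyond the scatter is expected in this assay, and compound 4 is estimated at 3.5 ug/mL, within 1.5 ug/mL to 8 ug/mL, which amounts to an expected step of a 1.1-fold lower number from compound 3 to compound 4 (0.05 log units; within the scatter).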

Compound 4, half-maximal inhibitory concentration: 4.2 ug/mL
Estimate against measurement, compound 4: 1.2-fold (0.08 log units) below; low and high end bracket the measured number.
By their numbers in this assay, from the lowest: compounds 2, 1, 3 and 4 (each within the scatter of the next).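

For the compounds shown here, every earlier step changed the sulfonyl-bearing ring, so compound 4 gives the first look at the other ring of the shared core, with dimethylamino in place of hydrogen on an aromatic carbon, para to a large group. In this assay this change gives a 1.1-fold higher number from compound 3 to compound 4 (0.03 log units; within the scatter) and so cannot be told apart from repeated measurement of a single compound, even though a hydrogen atom gives way to a group of 3 heavy atoms. The result therefore shows that, with bromo on the sulfonyl-bearing ring, this one substitution at this position leaves the read-out unresolved from that of compound 3, but no measurement shown here offers an explanation for this.

The compounds shown leave open whether a different group at this same place, such as a carboxylic acid, a primary amine or a longer alkyl chain, would move the read-out beyond the scatter. They also leave open whether dimethylamino would give a similar result when paired with fluoro or hydrogen on the sulfonyl-bearing ring instead of bromo.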